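The compounds below may be only part of what the source reports. "The series", "measured", "known", "first", "only" and "open" are said of these compounds alone.

Compounds measured so far:
compound 1 `COc1cc(C(=O)/C=C\Nc2ccc(-c3nc4cc(OC)c(OC)c(OC)c4s3)cc2C)cc(OC)c1OC` – 12900 nM
compound 2 `COc1cc(OC)c2sc(-c3ccc(N/C=C\C(=O)c4cc(OC)c(OC)c(OC)c4)cc3)nc2c1` – 15800 nM

The account concerns two measured compounds and one that awaits measurement. In a functional assay on MDA-MB-231 cells (Homo sapiens) for antiproliferative activity, read by sulforhodamine B assay, with a stated time of 48 h (on this read-out higher numbers stand for weaker inhibition and lower numbers for stronger inhibition), compound 1 gives 12900 nM, and in this assay compound 2 gives 15800 nM. Compound 2 carries the highest of the two numbers, but its nearest neighbour, compound 1, lies within the scatter of it, so the two stand level on the evidence at hand.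

Compound 3 `COc1cc(OC)c2sc(-c3ccc(N/C=C\C(=O)c4ccc(OC)c(F)c4)cc3)nc2c1` is the untested member. It differs from compound 2 in a single place: 3-fluoro-4-methoxyphenyl in place of 3,4,5-trimethoxyphenyl on a carbonyl carbon. Among the compounds with values here, no step between two measured compounds of this set shows what such a change does, so the expectation rests on the values of compound 2 alone and on the size of the change.

The step from compound 2 to compound 3 is expected to be a 1.6-fold higher number from compound 2 to compound 3 (0.20 log units; within the scatter), pointing toward a higher number, a weakening that may not clear the scatter. For compound 3 in this assay the estimate is 25000 nM, within a range from 8000 nM to 80000 nM.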

Compound 3, half-maximal inhibitory concentration: 6700 nM
Estimate against measurement, compound 3: 3.7-fold (0.57 log units) above, and the stated range ends above it.
By their numbers in this assay, from the lowest: compounds 3, 1 and 2 (each within the scatter of the next, the first and the last beyond it).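

In this assay, within the data shown here, 3-fluoro-4-methoxyphenyl in place of 3,4,5-trimethoxyphenyl on the carbonyl carbon gives a 2.4-fold lower number from compound 2 to compound 3 (0.37 log units; beyond the scatter), a modest step but one beyond the scatter, and the first step in this set that can be read at all. It shows that, on the core shared by compound 2 and compound 3, 3,4,5-trimethoxyphenyl is not required at this place for this level of activity: the entering group has fewer heavy atoms and fewer hydrogen-bond acceptors, yet it goes with stronger inhibition. Nothing given here explains the size or direction of this step.

The change removes methoxy groups and brings in a fluorine in a single move, so this one pair cannot show which of these alterations accounts for the step. It also leaves open whether a chlorine or a hydroxyl group in place of the fluorine would hold the gain, and whether the same exchange would give a step of similar size on the core of compound 1.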